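The source may report more compounds than this note shows. Statements on the series, on what has been measured and on what is new or still open speak of the compounds shown alone.

Measured compounds:
- compound 1, `Cc1ccc(S(=O)(=O)N[C@H]2CC[C@@H](F)[C@@H]2C/C=C\CCCC(=O)O)cc1`, 260 nM
- compound 2, `O=C(O)CCC/C=C\CC1=CCC[C@@H]1NS(=O)(=O)c1ccccc1`, 2300 nM
- compound 3, `O=C(O)COCCCCC1=CCC[C@@H]1NS(=O)(=O)c1ccc(Cl)c(Cl)c1`, 1900 nM

All three were read in a functional assay on a cell-free system (plasma) for inhibition of thromboxane A2 receptor (Homo sapiens), read by turbidimetry; on this read-out higher numbers stand for weaker inhibition and lower numbers for stronger inhibition. On these numbers compound 2 stands highest of the three. Compound 3 sits nearest; its value and that of compound 2 lie within the scatter, so no order between the two is claimed. Compound 1 lies furthest, its number lower than that of compound 2 by a margin beyond the scatter. Going by the values given here, none of the three pairs differs in only one place, so no single-change step is available from the measured set.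

Compound 4, `O=C(O)CCC/C=C\CC1=CCC[C@@H]1NS(=O)(=O)c1ccccc1[N+](=O)[O-]`, is not yet measured. It differs from compound 2 by nitro in place of hydrogen on an aromatic carbon of a six-membered aromatic ring of carbon only, ortho to a large group. Among the compounds with values here, no measured pair shows what a nitro group does, so the expectation rests on compound 2 alone. In this assay the step is expected to be small, if anything toward a lower number, and probably not beyond the scatter; the expected step is a 1.5-fold lower number from compound 2 to compound 4 (0.19 log units; within the scatter). Compound 4 is expected at 1500 nM, with a range from 500 nM to 5000 nM.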

Compound 4, half-maximal inhibitory concentration: 680 nM
The estimate for compound 4 lay 2.2-fold (0.34 log units) above the measured number, and the stated range covers the measured number.
By their numbers in this assay, from the lowest: compound 1; then compound 4; then compounds 3 and 2 (each within the scatter of the next).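

Going by these compounds alone, the only single-change step so far is phenyl to 2-nitrophenyl: in this assay, it gives a 3.4-fold lower number from compound 2 to compound 4 (0.53 log units; beyond the scatter). Within the data shown here, this aromatic carbon, ortho to a large group, therefore accepts a nitro group, with its 3 heavy atoms, without a loss of inhibition, and the read-out moves toward stronger inhibition by a margin that the earlier compounds could not show. Nothing available explains why this step occurs.

Going by these compounds, it remains open whether the gain belongs to nitro itself or would also appear with another group at this place, such as an amine or a methoxy group. Also unresolved is whether a nitro group on another carbon of the ring, or on the core of compound 1, would give a step of similar size.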